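This account rests on a few compounds, and the source may have more. Where it says the series, first, only, none or still open, it means among the compounds named here.

In a functional assay on NUGC-3 cells (Homo sapiens) for inhibition, read by sulforhodamine B assay, with a stated time of 48 h (a lower number here means a stronger inhibitor of growth, a higher number a weaker inhibitor of growth), compound 1, with the structure `COc1ccccc1NC(=O)c1nccc2ccccc12`, gives > 10000 nM, which is a limit of the assay rather than a measured number. Compound 3, with the structure `COc1ccccc1NC(=O)C1NCCc2ccccc21`, also reaches only a limit in this assay, giving > 10000 nM. Within the data shown here, compound 2, with the structure `O=C(Nc1ccc(C(F)(F)F)cc1)C1c2ccccc2CCN1C(=O)c1ccc(Cl)cc1`, is the one compound of the three with a real number in this assay, at 4200 nM. Compound 1 therefore stands at the limit of > 10000 nM in this assay, at which 2 of the 3 values shown sit. The move from compound 1 to compound 4, whose structure is `O=C(Nc1ccccc1Cl)c1nccc2ccccc12`, is a single swap: chloro in place of methoxy on an aromatic carbon. Among the measured compounds shown here, no measured pair in this set shows what such a swap does, and compound 1 itself sits at the limit, so the expectation in this assay is for no change beyond the usual scatter, in either direction. Compound 4 is expected to give about 10000 nM, in a range from 4000 nM to 30000 nM. The estimated step of a number no higher from compound 1 to compound 4 (the limit leaves the size open) means that a result at or near the limit is the expected outcome.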

Compound 4, concentration for 50% growth inhibition: > 10000 nM
Compound 4: no number, only a limit; the forecaster's own chance of this, stated with the estimate: 70%; the middle value lies on the limit itself.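

Compound 1 and compound 4 each reach only a limit in this assay, not a number, so no step can be read for chloro in place of methoxy: the limit of > 10000 nM in this assay, at which 3 of the 4 values shown sit.

The compounds shown leave open how strongly either one inhibits growth, and whether this swap changes it at all.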